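Pyrazoline-linked coumarins: oral paw edema inhibition, series notes

A few compounds are considered here, and "the series" means these few. Any claim that something is new, unique, unknown or untested is made for them only; others in the source may bear on it.

Measured compounds:
compound 1 `COc1ccc([C@H]2CC(c3cc4ccccc4oc3=O)=NN2c2ccccc2)cc1` gives 24.8%
compound 2 `O=c1oc2ccccc2cc1C1=NN(c2ccccc2)[C@@H](c2cccc([N+](=O)[O-])c2)C1` gives 26.1%
compound 3 `O=c1oc2ccccc2cc1C1=NN(c2ccccc2)[C@@H](c2ccc(F)cc2)C1` gives 44.9%

All three were run in a functional assay on the whole organism (strain albino) for inhibition, with Rattus norvegicus as the target, read by paw edema, with stated times of 1 h and 2 h, at a dose of 200 mg/kg by the oral route; a higher number here means more inhibition at the dose given (going by the name of the read-out), a lower number less inhibition. Compound 1 stands lowest of the three numbers, with compound 2 within the scatter of it (a number 1.3 percentage points higher from compound 1 to compound 2 (within the scatter)) and compound 3 further off (a number 20.1 percentage points higher from compound 1 to compound 3 (beyond the scatter)). The other measured step, a number 18.8 percentage points higher from compound 2 to compound 3 (beyond the scatter), likewise lies beyond the scatter.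

Compound 4 `O=c1oc2ccccc2cc1C1=NN(c2ccccc2)[C@@H](c2ccc(O)cc2)C1` is not yet measured. It differs from compound 1 by hydrogen in place of methyl on an oxygen on an aromatic ring. Going by the values given here, no measured step changes the group on that oxygen; the nearest comparison is the replacement of methoxy by fluoro from compound 1 to compound 3, which is a different change, and the swap of aryl groups from compound 1 to compound 2 stayed within the scatter. Among the compounds with values here, with no step that bears directly on this change, nothing beyond the scatter is expected in this assay, with a wide allowance either way.

Compound 4 is therefore expected to give about 30%, between 15% and 48%, which would mean an estimated step of a number 5.2 percentage points higher from compound 1 to compound 4 (within the scatter).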

Compound 4, a percentage reported as inhibition, in the whole organism at one dose (the size of the read-out at that dose, not a potency): 28.8%
Compound 4: middle estimate off by 1.2 percentage points, on the high side; measured number inside the range.
By their numbers in this assay, from the lowest: compounds 1, 2 and 4 (each within the scatter of the next); then compound 3.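

In this assay, going by these compounds alone, the first direct reading of the group on this oxygen is a number 4 percentage points higher from compound 1 to compound 4 (within the scatter), so hydrogen in place of methyl on an oxygen on an aromatic ring does not separate the two compounds. The 4-hydroxyphenyl compound also stays level with the 3-nitrophenyl compound, a number 2.7 percentage points higher from compound 2 to compound 4 (within the scatter), while hydroxy in place of fluoro on an aromatic carbon gives a number 16.1 percentage points lower from compound 3 to compound 4 (beyond the scatter), so among the four compounds only compound 3 stands apart, with none going against this. Nothing at hand explains either the level readings or the gap to compound 3.

Still open, from the compounds shown here alone, is whether the gap belongs to fluoro alone or would also appear with chloro or bromo on that aromatic carbon. The compounds shown also leave open how an amine, a carboxylic acid or a longer chain on the oxygen, such as ethoxy, would read.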